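The source may hold more compounds than are shown below. What is called first, only, known or untested is meant among the compounds shown, and "the series" means these compounds.

In an ADME assay on PC-3 cells (Homo sapiens) for cytotoxicity, read by WST assay, tested at 100 uM (a higher number here means more inhibition at the concentration tested (going by the name of the read-out), a lower number less inhibition), compound 1 `O=C(Nc1ccc(Cl)cn1)C1CCCN(C(=O)c2cc(C(F)(F)F)cc(C(F)(F)F)c2)C1` gives 0%. Among the measured compounds shown here, compound 2 `O=C(Nc1ccc(Cl)cc1)C1CCCN(C(=O)c2cccc(-c3cccs3)c2)C1` gives 4% in this assay, which places it at the top of the two numbers so far, though the figure of compound 1 sits within the usual scatter of it, so the two compounds cannot be told apart on these readings. Both show almost no inhibition at the concentration tested.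

Compound 3 `CC(C)(C)CC(=O)Nc1cccc(C(=O)N2CCCC(C(=O)Nc3ccc(Cl)cc3)C2)c1` has not yet been measured in this assay. It differs from compound 2 in one place: (neopentylcarbonyl)amino in place of thiophen-2-yl on an aromatic carbon. For the measured compounds named here, the two measured compounds share no step that would show what such a change does here, and neither of them reaches a level of inhibition from which a fall could even be seen. The expectation for compound 3 is therefore a step from compound 2 of a number 1 percentage points lower from compound 2 to compound 3 (within the scatter), that is, none beyond the scatter. Compound 3 is thus estimated to give about 3% in this assay, with a range from 0% to 15%.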

Compound 3, a percentage reported as inhibition, at one concentration (the size of the read-out at that concentration, not a potency): 0%
Compound 3: the middle estimate sits 3 percentage points above what was measured; low and high end bracket the measured number.
By their numbers in this assay, from the lowest: compounds 1, 3 and 2 (each within the scatter of the next).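

In this assay, the swap of thiophen-2-yl for (neopentylcarbonyl)amino on an aromatic carbon, meta to a large group, reads as a number 4 percentage points lower from compound 2 to compound 3 (within the scatter), so compound 2 and compound 3 cannot be told apart. Among the compounds shown here, this is the first step that can be read at this place, and it shows that an open chain with no ring and a hydrogen-bond donor can stand in for a five-membered aromatic ring without the reading moving beyond the scatter. Nothing measured here explains this result or bears on it.

Since compound 2 and compound 3 both show almost no inhibition at the concentration tested, the compounds shown leave open whether any group at this place could bring a clear rise in inhibition, such as a primary amine, a carboxylic acid or a longer alkyl chain. They also leave open whether the same swap would read alike on the core of compound 1, which carries a different set of groups.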